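The source may hold more compounds than are shown below. What is called first, only, known or untested is meant among the compounds shown, and "the series" means these compounds.

Compound 1 `Clc1ccc(Nc2nc(-c3ccccn3)cs2)nc1` is measured in an ADME assay on KB cells (Homo sapiens) for cytotoxicity, read by MTT assay, with a stated time of 72 h (a higher number here means that more compound is tolerated, a lower number that less compound is tolerated), where compound 1 gives 98600 nM. Its only companion, compound 2 `FC(F)(F)c1ccc(-c2csc(Nc3ccc(Cl)cn3)n2)nc1`, gives 35400 nM in this assay, so compound 1 stands highest of the two numbers shown. Going by the values given here, the single known step is a 2.8-fold lower number from compound 1 to compound 2 (0.44 log units; beyond the scatter), a modest one that arises from trifluoromethyl in place of hydrogen on an aromatic carbon.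

Compound 3 `Clc1ccc(Nc2nc(-c3ncccn3)cs2)nc1` differs from compound 1 in another way: pyrimidin-2-yl in place of pyridin-2-yl on an aromatic carbon. The measured step concerns a different group at a different place, so nothing measured bears directly on this exchange. With no guidance beyond that, the expected step in this assay is none beyond the scatter, and compound 3 is estimated at 85000 nM, within a range from 30000 nM to 200000 nM, which means an expected step of a 1.2-fold lower number from compound 1 to compound 3 (0.06 log units; within the scatter).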

Compound 3, half-maximal cytotoxic concentration: 20700 nM
For compound 3 the middle estimate is 4.1-fold (0.61 log units) above the measured one; the whole stated range lies above it.
By their numbers in this assay, from the lowest: compounds 3 and 2 (each within the scatter of the next); then compound 1.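

Exchanging pyridin-2-yl for pyrimidin-2-yl on this aromatic carbon gives a 4.8-fold lower number from compound 1 to compound 3 (0.68 log units; beyond the scatter) in this assay, although the entering group has the same number of heavy atoms as the leaving one, with a nitrogen where a carbon stood. The position next to the ring nitrogen therefore responds to a small change within the attached ring, and here the cells tolerate less compound. Nothing available explains why this exchange has such an effect.

The compounds shown do not tell whether it is the added ring nitrogen itself that matters, or how a plain phenyl ring or an amine at this position would compare. They also leave open whether trifluoromethyl on the pyrimidin-2-yl ring would shift the number further.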